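Butyl for Fluoro on the Benzyl of Compound 3

The compounds below may be only part of what the source reports. "The series", "measured", "known", "first", "only" and "open" are said of these compounds alone.

Compound 3 `C/C(=C\C(=O)Nc1ccccc1OCCCC(=O)O)c1ccc2c(ccn2Cc2ccc(F)cc2)c1` gives 97 nM in an assay on Prostate gland for inhibition of steroid 5-alpha-reductase (Rattus norvegicus) (on this read-out lower numbers stand for stronger inhibition and higher numbers for weaker inhibition), the second highest of the three numbers measured. Compound 1 `CCCCn1ccc2cc(/C(C)=C/C(=O)Nc3ccccc3OCCCC(=O)O)ccc21` gives 43 nM, and compound 2 `C/C(=C\C(=O)Nc1ccccc1OCCCC(=O)O)c1ccc2c(ccn2CC(C)C)c1` gives 160 nM. All three measured steps change the group on the aromatic nitrogen: a 3.7-fold higher number from compound 1 to compound 2 (0.57 log units; beyond the scatter), a 2.3-fold higher number from compound 1 to compound 3 (0.35 log units; beyond the scatter) and a 1.6-fold lower number from compound 2 to compound 3 (0.22 log units; within the scatter). Compound 4 `CCCCc1ccc(Cn2ccc3cc(/C(C)=C/C(=O)Nc4ccccc4OCCCC(=O)O)ccc32)cc1` differs from compound 3 in one place: butyl in place of fluoro on an aromatic carbon. For the measured compounds named here, no measured step alters a group at that place, so the data give no direction for this change, and the step is expected to stay within the scatter: a 1.1-fold lower number from compound 3 to compound 4 (0.06 log units; within the scatter). Compound 4 is therefore estimated at 85 nM, with a range from 30 nM to 250 nM.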

Compound 4, half-maximal inhibitory concentration: 100 nM
The estimate for compound 4 lay 1.2-fold (0.07 log units) below the measured number, within the range that was stated.
By their numbers in this assay, from the lowest: compound 1; then compounds 3, 4 and 2 (each within the scatter of the next).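

Replacing fluoro with butyl on this aromatic carbon, turning 4-fluorobenzyl into 4-butylbenzyl, gives a 1.0-fold higher number from compound 3 to compound 4 (0.01 log units; within the scatter), so in this assay this place accepts the larger alkyl chain with no readable change. For the compounds shown here, with 4-butylphenyl in place of isopropyl the result is a 1.6-fold lower number from compound 2 to compound 4 (0.20 log units; within the scatter), and with it in place of propyl the result is a 2.3-fold higher number from compound 1 to compound 4 (0.37 log units; beyond the scatter), the only new step beyond the scatter. Nothing available accounts for these results. From the compounds shown here alone, whether an amine or a carboxylic acid at this aromatic carbon would fit equally remains open. So does a longer chain in place of butyl.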